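Swapping one amine tail for another in compound 4

A few compounds are considered here, and "the series" means these few. Any claim that something is new, unique, unknown or untested is made for them only; others in the source may bear on it.

Compound 1, `Cc1ccccc1NC(=O)CCC(=O)OCCCCCCSc1ccc([N+](=O)[O-])c2nonc12`, gives 440 nM in an assay on isolated protein for inhibition of glutathione S-transferase Mu 2 (Homo sapiens), with a stated time of 10 min; a lower number here means a stronger inhibitor, a higher number a weaker inhibitor.
Compound 2, `O=C(CCC(=O)OCCCCCCSc1ccc([N+](=O)[O-])c2nonc12)Nc1cccc(Cl)c1`, gives 1100 nM in this assay.
Compound 3, `CN(C)CCCNC(=O)CCC(=O)OCCCCCCSc1ccc([N+](=O)[O-])c2nonc12`, gives 90 nM in this assay.

Compound 3 stands at the lowest number of the three, and its lead is real: the step of a 4.9-fold lower number from compound 1 to compound 3 (0.69 log units; beyond the scatter) and the step of a 12-fold lower number from compound 2 to compound 3 (1.09 log units; beyond the scatter) both lie beyond the scatter. Compound 4, `O=C(CCC(=O)OCCCCCCSc1ccc([N+](=O)[O-])c2nonc12)NCCN1CCCC1`, differs from compound 3 by pyrrolidin-1-yl in place of (dimethylamino)methyl on a saturated chain carbon, two bonds along the chain from an amide-type nitrogen. Within the data shown here, every measured step so far exchanges an aromatic ring on the amide nitrogen for a chain carrying a basic amine, including a 2.5-fold higher number from compound 1 to compound 2 (0.40 log units; beyond the scatter) between two rings; none compares two such amine chains with each other. The change to compound 4 keeps the amine chain, so compound 4 is expected to show a step of no change at the digits printed from compound 3 to compound 4 (within the scatter) that stays within the scatter. The estimate for compound 4 is therefore 90 nM, with a range from 40 nM to 220 nM.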

Compound 4, half-maximal inhibitory concentration: 200 nM
Compound 4: middle estimate off by 2.2-fold (0.35 log units), on the low side; measured number inside the range.
By their numbers in this assay, from the lowest: compound 3; then compound 4; then compound 1; then compound 2.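

Among these compounds, this is the first comparison of two amine chains on the amide nitrogen, and in this assay they are not interchangeable: putting 2-(pyrrolidin-1-yl)ethyl in place of 3-(dimethylamino)propyl gives (a 2.2-fold higher number from compound 3 to compound 4 (0.35 log units; beyond the scatter)). The new chain still beats both aromatic rings (a 5.5-fold lower number from compound 2 to compound 4 (0.74 log units; beyond the scatter); a 2.2-fold lower number from compound 1 to compound 4 (0.34 log units; beyond the scatter)). No measurement shown here accounts for the difference between the two amine chains.

As far as these compounds go, this change alters the amine and the chain together, so it remains open which of them matters. A 2-(dimethylamino)ethyl or 3-(pyrrolidin-1-yl)propyl chain would separate the two.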